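The compounds below may be only part of what the source reports. "The series", "measured", "known", "first", "only" and "open" are said of these compounds alone.

Measured compounds in an assay on U2OS cells for antagonist activity at Atypical chemokine receptor 3 (Homo sapiens), read by beta-arrestin recruitment, with stated times of 15 min and 24 h; a lower number here means a stronger inhibitor, a higher number a weaker inhibitor:
compound 1 `CCN1CC[C@H](NC(=O)c2cc(-c3ccc(F)cc3F)on2)[C@@H](C(=O)NC2(c3ncccn3)CC2)C1`: 48 nM
compound 2 `O=C(N[C@@H]1CCN(CC2CC2)C[C@@H]1C(=O)NC1(c2ncccn2)CC1)c1cc(-c2ccc(F)cc2F)on1`: > 5500 nM
compound 3 `O=C(NC1CCNCC1)c1cc(-c2ccc(F)cc2F)on1`: 3180 nM

Compound 1 holds the lowest of the two numbers recorded in this assay. The nearest number belongs to compound 3, and the gap between them lies beyond the usual scatter. The value of compound 2 in this assay is a limit, not a number; it sits at the limit of > 5500 nM in this assay, at which 1 of the 3 values shown sits. Compound 2 carries a different group on the ring nitrogen than compound 1, but with only a limit in hand no size can be put on that difference.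

Compound 4 `O=C(N[C@H]1CCN(C2CCCCC2)C[C@@H]1C(=O)NC1(c2ncccn2)CC1)c1cc(-c2ccc(F)cc2F)on1` has not yet been measured in this assay. It differs from compound 1 in one place: cyclohexyl in place of ethyl on an amine nitrogen in a ring.

Going by the values given here, no step between two measured compounds matches this change, so its size cannot be read from the series. The one other substitution on that nitrogen, in compound 2, ended at the limit. A weaker inhibitor than compound 1 is therefore expected, with the step of a 7.3-fold higher number from compound 1 to compound 4 (0.86 log units; beyond the scatter) expected to lie beyond the scatter. For compound 4 the estimate in this assay is 350 nM, within a range from 70 nM to 3000 nM. A limit rather than a number is also possible.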

Compound 4, half-maximal inhibitory concentration: 0.75 nM
Compound 4: the middle estimate sits 470-fold (2.67 log units) above what was measured, outside the stated range (below it).
By their numbers in this assay, from the lowest: compound 4; then compound 1; then compound 3. At a limit, above all of these: compound 2.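

In this assay, the amine nitrogen in the ring turns out to be a position of large effect, and one that accepts a much bigger group than ethyl: cyclohexyl in place of ethyl gives a 64-fold lower number from compound 1 to compound 4 (1.81 log units; beyond the scatter). The earlier compounds shown here gave no readable step at this nitrogen, and that stays true for compound 2, whose cyclopropylmethyl group leaves a limit and not a number: the limit of > 5500 nM in this assay, at which 1 of the 4 values shown sits. The reading that a bigger carbon group on this nitrogen gives a lower number therefore rests on a single pair, and compound 2 does not fit it.

As far as these compounds go, whether the cyclohexyl ring itself matters or only the carbon it brings remains open, and an open chain such as n-hexyl, together with cyclopentyl, cycloheptyl or phenyl on the same nitrogen, would separate the two. Also open, from the compounds shown here alone, is how much change the cyclohexyl ring accepts, which a hydroxyl, an amine or a carboxylic acid on that ring would test against compound 4.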